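The source may hold more compounds than are shown below. What is called first, only, known or untested is meant among the compounds shown, and "the series" means these compounds.

Series notes. Of the compounds shown here, three of the shared core have been measured so far: compound 1 `O=C1CSC(c2cccc(Cl)c2)N1CCN1CCCCC1`, compound 2 `O=C1CSC(c2ccc([N+](=O)[O-])cc2)N1CCN1CCCCC1` and compound 3 `O=C1CSC(c2ccccc2[N+](=O)[O-])N1CCN1CCCCC1`. In an ADME assay on Vero cells (Chlorocebus sabaeus) for cytotoxicity, read by neutral red uptake, tested at 3150 ug/mL (a lower number here means a stronger effect, a higher number a weaker effect of the compound at the concentration tested), compound 1 gives 15%. In this assay compound 2 gives 10%, a number within the scatter of that of compound 1, so the two cannot be told apart. In this assay compound 3 gives 30%, a number that lies beyond the scatter away from compound 1 toward the weaker side. Among the three numbers compound 1 thus stands second highest, closest to compound 2 and furthest from compound 3. Among the compounds with values here, no pair of measured compounds differs in a single place, so the effect of an exchange of the aryl group cannot be read off from measured steps. Compound 4 `O=C1CSC(c2ccc(F)cc2)N1CCN1CCCCC1` differs from compound 1 in one place: 4-fluorophenyl in place of 3-chlorophenyl on a saturated ring carbon. Because the measured numbers of compound 1, compound 2 and compound 3 span only a narrow band, no step beyond the scatter is expected no change at the digits printed from compound 1 to compound 4 (within the scatter). Compound 4 is accordingly estimated at 15%, with a range from 5% to 30%.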

Compound 4, a percentage reported as activity, at one concentration (the size of the read-out at that concentration, not a potency): 11%
Compound 4: middle estimate off by 4 percentage points, on the high side, and the stated range covers the measured number.
By their numbers in this assay, from the lowest: compounds 2, 4 and 1 (each within the scatter of the next); then compound 3.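

In this assay the series now has its first single-place steps: a number 4 percentage points lower from compound 1 to compound 4 (within the scatter) with 4-fluorophenyl in place of 3-chlorophenyl on the saturated ring carbon, and a number 1 percentage points higher from compound 2 to compound 4 (within the scatter) with fluoro in place of nitro on an aromatic carbon. Both steps lie within the scatter, so neither exchange separates the compounds involved, and the read-out at this position does not distinguish these aryl groups. No measurement at hand bears on this result.

Compound 3 still has no partner that differs from it in one place, so its number stays unconnected to any step. On these data alone, how an aromatic ring carrying a carboxylic acid or a dimethylamino group would behave in this assay remains open, as does a longer chain on the ring nitrogen.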